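Pyrazolopyrimidine series: vinylphenyl replacement at the aryl position

The source may hold more compounds than are shown below. What is called first, only, known or untested is meant among the compounds shown, and "the series" means these compounds.

Measured so far in a functional assay on A549 cells (Homo sapiens) for inhibition, read by CCK-8 assay, with a stated time of 48 h; on this read-out higher numbers stand for weaker inhibition and lower numbers for stronger inhibition:
compound 1, `COc1ccc(-c2cc3nccc(-c4cc(OC)c(OC)c(OC)c4)n3n2)cc1F`, 545 nM
compound 2, `Cc1ccc(-c2cc3nccc(-c4ccc(F)cc4)n3n2)cc1`, a limit of the assay, > 10000 nM
compound 3, `COc1cc(-c2ccnc3cc(-c4cccc5c4ccn5CO)nn23)cc(OC)c1OC`, 1100 nM

Compound 1 gives the lowest of the two numbers available in this assay, and compound 3 sits within the scatter of it, so the two cannot be placed in order. The entry for compound 2 is a limit, as noted in the limit of > 10000 nM in this assay, at which 1 of the 3 values shown sits; the compound is not distinguished further. Among the measured compounds shown here, compound 2 and compound 3 each differ from compound 1 in more than one place, so no single step between measured compounds can be isolated here.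

Compound 4, `C=Cc1ccc(-c2cc3nccc(-c4cc(OC)c(OC)c(OC)c4)n3n2)cc1`, is not yet measured in this assay. It differs from compound 1 as follows: 4-vinylphenyl in place of 3-fluoro-4-methoxyphenyl on an aromatic carbon. For the measured compounds named here, with no measured step of this kind to lean on, the expectation is a change of no more than the scatter, if anything a small loss, since the hydrogen-bond acceptor counted on the leaving group is absent from the entering group. Compound 4 is therefore expected to give about 900 nM in this assay, with a range from 300 nM to 3000 nM. That estimate means a step of a 1.7-fold higher number from compound 1 to compound 4 (0.22 log units; within the scatter), expected to lie at the edge of the scatter.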

Compound 4, half-maximal inhibitory concentration: 1030 nM
Estimate against measurement, compound 4: 1.1-fold (0.06 log units) below; low and high end bracket the measured number.
By their numbers in this assay, from the lowest: compounds 1, 4 and 3 (each within the scatter of the next). At a limit, above all of these: compound 2.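

In this assay, among the compounds shown here, 4-vinylphenyl in place of 3-fluoro-4-methoxyphenyl on this aromatic carbon gives a 1.9-fold higher number from compound 1 to compound 4 (0.28 log units; within the scatter) and is the first step that isolates a single place. With the rest of compound 1 unchanged, neither the fluorine nor the methoxy oxygen, which carries the hydrogen-bond acceptor counted on the leaving group, is needed to keep the read-out within the scatter of compound 1, and a carbon-only vinyl substituent serves as well on this evidence. Nothing measured here bears on a cause for this step.

Still open, as far as these compounds go, is how this position responds to a primary amine or a carboxylic acid on the phenyl ring, and whether the fluorine and the methoxy group count separately when each is changed alone. Compound 2 gives > 10000 nM as a limit of the assay and differs from compound 1 in more than one place, so it does not show which of its changes matters.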